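Amide-side aryl changes in the series: notes

The source may hold more compounds than are shown below. What is called first, only, known or untested is meant among the compounds shown, and "the series" means these compounds.

Three compounds share one core and differ only in the aryl group on the amide nitrogen. Compound 1 `O=C(CCC(=O)OCCCCCCSc1ccc([N+](=O)[O-])c2nonc12)Nc1ccccc1F` gives 9890 nM in an assay on isolated protein for inhibition of glutathione S-transferase P (Homo sapiens), with a stated time of 10 min; on this read-out lower numbers stand for stronger inhibition and higher numbers for weaker inhibition. Compound 2 `O=C(CCC(=O)OCCCCCCSc1ccc([N+](=O)[O-])c2nonc12)Nc1ccccc1Cl` gives 15500 nM in this assay; the step of a 1.6-fold higher number from compound 1 to compound 2 (0.20 log units; within the scatter) separates the two halogen analogues. Compound 3 `Cc1ccccc1NC(=O)CCC(=O)OCCCCCCSc1ccc([N+](=O)[O-])c2nonc12` gives 4100 nM and stands lowest of the three, with a 2.4-fold lower number from compound 1 to compound 3 (0.38 log units; beyond the scatter) and a 3.8-fold lower number from compound 2 to compound 3 (0.58 log units; beyond the scatter) both beyond the scatter, so compound 3 is the most potent measured here.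

Compound 4 `O=C(CCC(=O)OCCCCCCSc1ccc([N+](=O)[O-])c2nonc12)Nc1cccc(Cl)c1` carries the change (3-chlorophenyl in place of 2-methylphenyl on an amide-type nitrogen). The measured steps that bear on it are the halogen-to-methyl exchanges, a 2.4-fold lower number from compound 1 to compound 3 (0.38 log units; beyond the scatter) and a 3.8-fold lower number from compound 2 to compound 3 (0.58 log units; beyond the scatter), where methyl gave the lower number each time. Run backwards, the chloro step would predict a modestly higher number, but that step concerned 2-chlorophenyl, and no measured pair reports what moving the substituent to the 3-position does. The expectation is therefore a modest rise in the number, around the reverse of the chloro step, with a wide range to cover the unmeasured position change.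

Compound 4 is estimated at 12000 nM in this assay, with a range of 4000 nM to 36000 nM, which means an expected step of a 2.9-fold higher number from compound 3 to compound 4 (0.47 log units; beyond the scatter).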

Compound 4, half-maximal inhibitory concentration: 28800 nM
Estimate against measurement, compound 4: 2.4-fold (0.38 log units) below; measured number inside the range.
By their numbers in this assay, from the lowest: compound 3; then compounds 1, 2 and 4 (each within the scatter of the next, the first and the last beyond it).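

Among these compounds, the exchange of 2-chlorophenyl for 3-chlorophenyl on the amide-type nitrogen gives the first reading on substituent position in this assay, and it stays within the scatter (a 1.9-fold higher number from compound 2 to compound 4 (0.27 log units; within the scatter)), so these four compounds do not separate the two chlorophenyl groups. Against the other two aryl groups, the picture is sharper: 3-chlorophenyl is clearly apart from 2-fluorophenyl (a 2.9-fold higher number from compound 1 to compound 4 (0.46 log units; beyond the scatter)), and replacing 2-methylphenyl gives the largest step in the set (a 7.0-fold higher number from compound 3 to compound 4 (0.85 log units; beyond the scatter)), so compound 3 now has the lowest number against all three halogen-bearing compounds, with none going against it. No measurement shown here accounts for these differences.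

Still open is whether the lower number belongs to the methyl group itself or to its place on the ring, as the compounds shown hold methyl at one position only and fluoro likewise. Also open, from the compounds shown here alone, is how a plain phenyl group, a methoxy group, an amine or a carboxylic acid on the aryl ring would read against compound 3, and whether a shorter or longer chain would change the order seen here.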